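Benzoxazole sulfonamides: moving the chloro on the sulfonyl ring

The compounds below may be only part of what the source reports. "The series", "measured", "known", "first", "only" and "open" are said of these compounds alone.

Compound 1 `O=S(=O)(Nc1ccc(-c2nc3ccccc3o2)cc1)c1cccc(Cl)c1` is one of three closely related sulfonamides examined in an assay on cells for inhibition of HSP60/HSP10 (Homo sapiens), with a stated time of 60 min (on this read-out higher numbers stand for weaker inhibition and lower numbers for stronger inhibition), where compound 1 gives 54000 nM. Compound 2 `O=S(=O)(Nc1ccc(-c2nc3cc(NS(=O)(=O)c4ccccc4F)ccc3o2)cc1)c1ccccc1F` gives 57000 nM in this assay, and compound 3 `O=S(=O)(Nc1ccc(-c2nc3ccccc3o2)cc1)c1cccc(C(F)(F)F)c1` gives 57000 nM. Among the measured compounds shown here, the only single-point step among them is a 1.1-fold higher number from compound 1 to compound 3 (0.02 log units; within the scatter), and the gap between compound 1 and compound 2 is likewise within the scatter, so compound 1 is separated from neither of its neighbours on this read-out.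

Compound 4 `O=S(=O)(Nc1ccc(-c2nc3ccccc3o2)cc1)c1ccccc1Cl` has not been measured. It differs from compound 1 by 2-chlorophenyl in place of 3-chlorophenyl on a sulfonyl sulfur. For the measured compounds named here, no measured step bears directly on this rearrangement; the nearest comparison is the step from compound 1 to compound 3, which exchanged the substituent on the same sulfonyl-bound ring and moved the number by a 1.1-fold higher number from compound 1 to compound 3 (0.02 log units; within the scatter). Given that, and the flat spread across compound 1, compound 2 and compound 3, no step beyond the scatter is expected, so the step of a 1.0-fold higher number from compound 1 to compound 4 (0.01 log units; within the scatter) is estimated to be small. Compound 4 is therefore expected to give about 55000 nM in this assay, within a range of 25000 nM to 120000 nM.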

Compound 4, half-maximal inhibitory concentration: > 100000 nM
Compound 4: a limit, no number; the forecaster's own chance of this, stated with the estimate: 20%; middle value at least 1.8-fold (0.25 log units) from the limit.
By their numbers in this assay, from the lowest: compounds 1, 2 and 3 (each within the scatter of the next). At a limit, above all of these: compound 4.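

Compound 4 gives a limit of the assay, not a number: the limit of > 100000 nM in this assay, at which 1 of the 4 values shown sits. Exchanging 3-chlorophenyl for 2-chlorophenyl on a sulfonyl sulfur gives an at least 1.8-fold higher number from compound 1 to compound 4 (0.26 log units; that floor lies within the scatter), so the true size of this step cannot be read and it cannot be placed beyond the scatter. Among the compounds shown here, the earlier step, a 1.1-fold higher number from compound 1 to compound 3 (0.02 log units; within the scatter), exchanged the substituent and kept the ring position, whereas this change keeps the same atoms and rearranges them, and it is the first to end at a limit rather than a number in this assay.

From the compounds shown here alone, it remains open whether the limit conceals a large step or a small one. Going by these compounds, it is also open whether an amine or a carboxylic acid in place of the chloro on the 2-chlorophenyl ring would return a number in this assay.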